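From iodo to chloro: notes on compound 3

This account rests on a few compounds, and the source may have more. Where it says the series, first, only, none or still open, it means among the compounds named here.

In a functional assay on U-87MG ATCC cells (Homo sapiens) for cytotoxicity, read by MTT assay, with a stated time of 48 h (a lower number here means a stronger inhibitor, a higher number a weaker inhibitor), compound 1 `CC(=NNC(=S)Nc1ccccc1)c1ccccn1` gives 1.4 nM and compound 2 `CC(=NNC(=S)Nc1ccc(I)cc1)c1ccccn1` gives 59 nM, so compound 2 holds the higher number of the pair and is the weaker inhibitor. For the measured compounds named here, the only measured step is a 42-fold higher number from compound 1 to compound 2 (1.62 log units; beyond the scatter), a large one beyond the scatter, for iodo in place of hydrogen on an aromatic carbon. Compound 3 `CC(=NNC(=S)Nc1ccc(Cl)cc1)c1ccccn1`, not yet measured, has chloro in place of iodo on an aromatic carbon. Going by the values given here, no measured compound carries chloro, so that step bears on the change only indirectly. It shows that the number in this assay can move strongly at this place. A halogen remains there, so a partial return towards compound 1 is expected. The expected change is a 3.0-fold lower number from compound 2 to compound 3 (0.47 log units; beyond the scatter), a moderate step to a lower number. The estimate for compound 3 is 20 nM, with an expected range of 4 nM to 80 nM.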

Compound 3, half-maximal inhibitory concentration: 1.7 nM
Compound 3: the middle estimate sits 12-fold (1.07 log units) above what was measured, and the stated range ends above it.
By their numbers in this assay, from the lowest: compounds 1 and 3 (each within the scatter of the next); then compound 2.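

In this assay, the exchange of one halogen for another at this place moves the number as far as the first step did, with a 35-fold lower number from compound 2 to compound 3 (1.54 log units; beyond the scatter) for chloro in place of iodo. Chloro and hydrogen on this aromatic carbon cannot be told apart, with a 1.2-fold higher number from compound 1 to compound 3 (0.08 log units; within the scatter) as the step between them. Among the three compounds, then, the higher number goes with iodo alone and not with the presence of a halogen as such, so this place tolerates at least one halogen without a step beyond the scatter.

On these data alone, whether bromo sides with chloro or with iodo remains open, as does the effect on the number of a non-halogen group here, such as an amine or methoxy. What separates chloro from iodo in this assay has no measured explanation here.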